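This account rests on a few compounds, and the source may have more. Where it says the series, first, only, none or still open, it means among the compounds named here.

Measured compounds:
- compound 1, `CC(C)C(=O)N1CC2CC(C1)N2`: in an assay on CHO cells for displacement of a labelled ligand from Neuronal acetylcholine receptor; alpha3/alpha6/beta2/beta3 (Homo sapiens), read by scintillation counting (a higher number here means a weaker inhibitor, a lower number a stronger inhibitor), compound 1 gives 580 nM
- compound 2, `O=C(C1CCCC1)N1CC2CC(C1)N2`: in this assay compound 2 gives 2900 nM

Among the measured compounds shown here, of the two numbers known so far, compound 1 holds the lower one. For the measured compounds named here, compound 2 sits higher, and the gap between the two is wider than the usual scatter of this assay; no step is computed between them, so only the two values themselves speak.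

The next compound, compound 3 `O=C([C@@H]1C[C@H]1F)N1CC2CC(C1)N2`, keeps the core of compound 1 and alters the acyl group: 2-fluorocyclopropyl in place of isopropyl on a carbonyl carbon. Going by the values given here, with no comparable step among the measured pairs, the size of this change is open. The new group is a small ring, nearer in bulk to the isopropyl it replaces than to the cyclopentyl of compound 2, so the expected step of a 1.2-fold higher number from compound 1 to compound 3 (0.08 log units; within the scatter) is small and not clearly beyond the scatter in either direction. Compound 3 is therefore estimated at 700 nM, within a range of 250 nM to 2000 nM.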

Compound 3, inhibition constant: 43 nM
For compound 3 the middle estimate is 16-fold (1.21 log units) above the measured one; measured number below the stated range.
By their numbers in this assay, from the lowest: compound 3; then compound 1; then compound 2.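

In this assay, the step from isopropyl to 2-fluorocyclopropyl on a carbonyl carbon is a 13-fold lower number from compound 1 to compound 3 (1.13 log units; beyond the scatter), so this position can lower the number sharply as well as raise it. Before this, the position had been seen only with plain carbon groups, and compound 2 at 2900 nM stood above compound 1 at 580 nM. Compound 3 now shows that a small ring carrying fluorine on this carbonyl carbon gives a far lower number than either of those values, though nothing shown here explains why.

Among the compounds shown here, the single step changes the ring and the fluorine together, and a plain cyclopropyl on the same carbonyl carbon would be needed to tell their shares apart. On these data alone, how the other stereoisomers of the 2-fluorocyclopropyl group compare also remains open.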